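The compounds below may be only part of what the source reports. "The series", "measured", "known", "first", "only" and "open" are said of these compounds alone.

Working notes on the series. In an ADME assay on CHO cells (Cricetulus griseus) for cytotoxicity, read by MTT assay, with a stated time of 24 h (a lower number here means that less compound is tolerated, a higher number that more compound is tolerated), compound 1 (`CC1Cn2c(nc([N+](=O)[O-])c2-c2ccc(CO)cc2)O1`) gives > 500000 nM, which is a limit of the assay and not a number. Compound 2 (`Cc1ccc(-c2c([N+](=O)[O-])nc3n2CC(C)O3)s1`) gives > 125000 nM, also a limit. Among the measured compounds shown here, these two limits set no order between the compounds, and no measured step between compounds differing in one place is available to size the next change. Compound 3 (`CC1Cn2c(nc([N+](=O)[O-])c2-c2ccc(OC(F)(F)F)cc2)O1`) has trifluoromethoxy in place of hydroxymethyl on an aromatic carbon of a six-membered aromatic ring of carbon only, para to a large group: trifluoromethoxy in place of hydroxymethyl on an aromatic carbon. A move beyond the scatter towards a lower number in this assay is expected, though its size is poorly fixed while the only reference is a limit. The estimated step is an at least 2.5-fold lower number from compound 1 to compound 3 (0.39 log units; beyond the scatter). For compound 3 the expected value is 200000 nM, with an estimated range of 60000 nM to 500000 nM, and a report as a limit alone is quite possible.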

Compound 3, half-maximal cytotoxic concentration: > 125000 nM
Compound 3: a limit, no number; the forecaster's own chance of this, stated with the estimate: 65%; the middle value lies beyond the limit too.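

Among the compounds shown here, compound 1 and compound 3 both stand as limits in this assay, and no step between them can be read. The compounds shown leave open where any of them would reach a half-maximal cytotoxic concentration, and whether trifluoromethoxy in place of hydroxymethyl changes it.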